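The source may report more compounds than this note shows. Statements on the series, on what has been measured and on what is new or still open speak of the compounds shown alone.

Among the measured compounds shown here, compound 2 `CC(C(=O)NCc1ccc(C(F)(F)F)cc1SCc1ccco1)c1ccc(NS(C)(=O)=O)c(F)c1` is the weaker of the two compounds measured so far: in an assay on CHO cells for antagonist activity at transient receptor potential cation channel subfamily V member 1 (Homo sapiens), read by FLIPR (on this read-out lower numbers stand for stronger inhibition and higher numbers for weaker inhibition), compound 2 gives 3.2 nM, while compound 1 `CC1CCN(c2cc(C(F)(F)F)ccc2CNC(=O)C(C)c2ccc(NS(C)(=O)=O)c(F)c2)CC1` gives 0.9 nM. For the measured compounds named here, the one step available, a 3.6-fold higher number from compound 1 to compound 2 (0.55 log units; beyond the scatter), swaps the group on the same aromatic carbon that is changed again below, and it moved the number only modestly.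

Compound 3 `COc1ccc(-c2cc(C(F)(F)F)ccc2CNC(=O)C(C)c2ccc(NS(C)(=O)=O)c(F)c2)cc1OC` differs from compound 2 in this way: 3,4-dimethoxyphenyl in place of ((furan-2-yl)methyl)sulfanyl on an aromatic carbon. Because the step of a 3.6-fold higher number from compound 1 to compound 2 (0.55 log units; beyond the scatter) shows that two quite different groups on this aromatic carbon both give strong inhibition, the new group is expected to be tolerated as well, and the number for compound 3 is expected to land near compound 2 or somewhat lower, a change of about a 1.6-fold lower number from compound 2 to compound 3 (0.20 log units; within the scatter). The estimate for compound 3 is therefore 2 nM, with a likely range from 0.5 nM to 8 nM.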

Compound 3, inhibition constant: 8.6 nM
Beside the measured number, compound 3's estimate is 4.3-fold (0.63 log units) below it, and the stated range ends below it.
By their numbers in this assay, from the lowest: compound 1; then compound 2; then compound 3.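

In this assay, this aromatic carbon also accepts 3,4-dimethoxyphenyl, but the number rises again (a 2.7-fold higher number from compound 2 to compound 3 (0.43 log units; beyond the scatter)) and rises further against the piperidine compound (a 9.6-fold higher number from compound 1 to compound 3 (0.98 log units; beyond the scatter)). The three groups on this carbon now fall into a clear order, with 4-methylpiperidin-1-yl giving the lowest number, ((furan-2-yl)methyl)sulfanyl the middle one and 3,4-dimethoxyphenyl the highest, so the position accepts very different groups but does not treat them alike. Nothing available here explains this order.

On these data alone, it remains open whether the rise belongs to the six-membered aromatic ring itself or to its two methoxy groups, which an unsubstituted phenyl group would help to separate. As far as these compounds go, it is also open how a small open-chain amine such as dimethylamino would compare with 4-methylpiperidin-1-yl on this carbon.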